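Methoxy in Place of Fluoro on the Pendant Phenyl

The compounds below may be only part of what the source reports. "The series", "measured", "known", "first", "only" and "open" are said of these compounds alone.

The measured compounds and their values:
compound 1 `Cc1cc(-c2ccccc2)c2ncc(CSCCc3ccccc3)n2c1` — 33 ug/mL
compound 2 `Cc1cc(-c2cccc(F)c2)c2ncc(CSCCc3ccccc3)n2c1` — 35 ug/mL
compound 3 `c1ccc(CCSCc2cnc3ccc(-c4ccccc4)cn23)cc1` — 9.9 ug/mL

In an ADME assay on HEL cells (Homo sapiens) for cytotoxicity, with a stated time of 3 days (a higher number here means that more compound is tolerated, a lower number that less compound is tolerated), compound 2 gives 35 ug/mL and stands highest of the three numbers. Compound 1 sits nearest to it, within the scatter, so the two cannot be ordered. Compound 3, which lacks the methyl on the shared core, gives 9.9 ug/mL and lies beyond the scatter below compound 2.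

Compound 4 `COc1cccc(-c2cc(C)cn3c(CSCCc4ccccc4)cnc23)c1` differs from compound 2 by methoxy in place of fluoro on an aromatic carbon. For the measured compounds named here, the only measured step that touches this part of the molecule is a 1.1-fold higher number from compound 1 to compound 2 (0.03 log units; within the scatter), and it lay within the scatter. Going by the values given here, no measured pair exchanges a fluoro for a methoxy, so the step in this assay from compound 2 to compound 4 is expected to be small, in no firm direction, and the estimate is a 1.2-fold lower number from compound 2 to compound 4 (0.07 log units; within the scatter). Compound 4 is therefore expected to give 30 ug/mL in this assay, with a plausible range from 15 ug/mL to 60 ug/mL.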

Compound 4, half-maximal cytotoxic concentration: > 50 ug/mL
Compound 4 was reported as a limit; the forecaster's own chance of this, stated with the estimate: 5%; middle value at least 1.6-fold (0.22 log units) away from the limit.
By their numbers in this assay, from the lowest: compound 3; then compounds 1 and 2 (each within the scatter of the next). At a limit, above all of these: compound 4.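

In this assay compound 4 is reported only as a limit, > 50 ug/mL, and it is the only compound shown that stands at it: the limit of > 50 ug/mL in this assay, at which 1 of the 4 values shown sits. At this place on the pendant phenyl, methoxy in place of fluoro gives an at least 1.4-fold higher number from compound 2 to compound 4 (0.15 log units; that floor lies within the scatter), and methoxy in place of hydrogen gives an at least 1.5-fold higher number from compound 1 to compound 4 (0.18 log units; that floor lies within the scatter). The fluoro step, a 1.1-fold higher number from compound 1 to compound 2 (0.03 log units; within the scatter), has a definite size, whereas these two have only a floor, so this position may respond to methoxy far more than it did to fluoro, or hardly at all.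

On these data alone, how far compound 4 lies beyond the limit stays open, and with it the true size of both steps. Also open, as far as these compounds go, are whether an amine or a carboxylic acid at this place would shift the number, and whether methoxy would act alike on the core of compound 3.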